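The source may report more compounds than this note shows. Statements on the series, on what has been measured and on what is new or still open speak of the compounds shown alone.

Compound 2 `CC(C)[C@H](NC(=O)COc1cccc2ccccc12)C(=O)N[C@@H](CC(=O)O)C(=O)COc1nccc2ccccc12` gives 106000 nM in a functional assay on Jurkat cells (Homo sapiens) for inhibition; on this read-out lower numbers stand for stronger inhibition and higher numbers for weaker inhibition; it holds the only number shown in this assay, the other value shown being not a number. Compound 1 `CCOC(=O)c1c(C)noc1OCC(=O)[C@H](CC(=O)O)NC(=O)[C@@H](NC(=O)COc1cccc2ccccc12)C(C)C` gives in this assay > 200000 nM, which is a limit of the assay, and (the limit of > 200000 nM in this assay, at which 1 of the 2 values shown sits). For the measured compounds named here, the one measured change at the oxygen on a saturated carbon is an at least 1.8-fold lower number from compound 1 to compound 2 (0.27 log units; that floor lies within the scatter), and no other step stands on that place. Compound 3 `CC(C)[C@H](NC(=O)COc1cccc2ccccc12)C(=O)N[C@@H](CC(=O)O)C(=O)COc1[nH]cnc2nncc1-2` differs from compound 2 by a group of 9 heavy atoms (5 carbon, 4 nitrogen; one five-membered aromatic ring with 2 hetero atoms, one six-membered aromatic ring with 2 hetero atoms) in place of a group of 10 heavy atoms (9 carbon, 1 nitrogen; one six-membered aromatic ring of carbon only, one six-membered aromatic ring with 1 hetero atom), on an oxygen on a saturated carbon. Going by the values given here, no measured pair shows this exchange, so it rests only on the single step at that position, whose floor lies within the scatter. For compound 3 a step of about a 1.1-fold lower number from compound 2 to compound 3 (0.03 log units; within the scatter) is therefore expected, not beyond the scatter in either direction. Compound 3 is accordingly estimated at 100000 nM in this assay, with a range from 30000 nM to 300000 nM.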

Compound 3, half-maximal inhibitory concentration: 161000 nM
Beside the measured number, compound 3's estimate is 1.6-fold (0.21 log units) below it; the measured number falls inside the stated range.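

In this assay, the exchange on an oxygen on a saturated carbon gives a 1.5-fold higher number from compound 2 to compound 3 (0.18 log units; within the scatter). This place therefore accepts a group with a five-membered and a six-membered aromatic ring and a hydrogen-bond donor, in place of isoquinolin-1-yl with no donor, without a step beyond the scatter. The reading against the oxazole-bearing group of compound 1 is only a floor, an at least 1.2-fold lower number from compound 1 to compound 3 (0.09 log units; that floor lies within the scatter), and compound 1 stands at a limit of the assay: the limit of > 200000 nM in this assay, at which 1 of the 3 values shown sits.

No step shown separates the three groups beyond the scatter, so what governs the number at this place remains unresolved. As far as these compounds go, it also remains open whether a plain phenyl group, or an aromatic group carrying an amine or a carboxylic acid, would move the number beyond the scatter.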